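This account rests on a few compounds, and the source may have more. Where it says the series, first, only, none or still open, it means among the compounds named here.

Working notes on the series. The shared core, seen in compound 1 `O=C(N/N=C/c1ccc(F)cc1)Nc1cc2c(Nc3ccc(F)c(Cl)c3)ncnc2cc1O[C@H]1CCOC1`, compound 2 `O=C(N/N=C/c1ccc([N+](=O)[O-])cc1)Nc1cc2c(Nc3ccc(F)c(Cl)c3)ncnc2cc1O[C@H]1CCOC1` and compound 3 `COc1ccc(/C=N/NC(=O)Nc2cc3c(Nc4ccc(F)c(Cl)c4)ncnc3cc2O[C@H]2CCOC2)cc1`, carries an aryl group on the carbon double-bonded to nitrogen. In a functional assay on PC-3 cells (Homo sapiens) for cytotoxicity, read by MTT assay, with a stated time of 72 h (on this read-out higher numbers stand for weaker inhibition and lower numbers for stronger inhibition), compound 1 is "not active" (no number reported). In this assay compound 2 gives 33500 nM, and compound 3 gives 34100 nM. Among the compounds with values here, the one change with both numbers, a 1.0-fold higher number from compound 2 to compound 3 (0.01 log units; within the scatter), is within the scatter, so compound 2 and compound 3 stand together, and nothing else bears on this position.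

Compound 4 `O=C(N/N=C/c1cc(Br)c(O)c(Br)c1)Nc1cc2c(Nc3ccc(F)c(Cl)c3)ncnc2cc1O[C@H]1CCOC1` differs from compound 2 by 3,5-dibromo-4-hydroxyphenyl in place of 4-nitrophenyl on a carbon with a double bond to nitrogen. Within the data shown here, only the step from compound 2 to compound 3 is comparable, and it was flat, so no shift beyond the scatter is expected: compound 4 is estimated at 33000 nM (range 12000 nM to 90000 nM), meaning an expected step of a 1.0-fold lower number from compound 2 to compound 4 (0.01 log units; within the scatter).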

Compound 4, half-maximal inhibitory concentration: 6160 nM
For compound 4 the middle estimate is 5.4-fold (0.73 log units) above the measured one; the whole stated range lies above it.
By their numbers in this assay, from the lowest: compound 4; then compounds 2 and 3 (each within the scatter of the next).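

The aryl group on the carbon with a double bond to nitrogen can move the number after all: this assay shows a 5.4-fold lower number from compound 2 to compound 4 (0.74 log units; beyond the scatter) and also a 5.5-fold lower number from compound 3 to compound 4 (0.74 log units; beyond the scatter) so this position is not flat, as the step between compound 2 and compound 3 alone had suggested. Nothing available gives a reason for this shift.

The compounds shown do not separate the two bromines from the hydroxyl, so it stays open which of them carries the step. From the compounds shown here alone, the effect of an amine or a carboxylic acid on this aryl ring also stays open.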